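The source may hold more compounds than are shown below. What is called first, only, known or untested is meant among the compounds shown, and "the series" means these compounds.

Compound 2, `CCCCCCCc1cc2cn(COCCO)c(=O)nc2o1`, is the starting point of this step. In a functional assay on HEL cells (Homo sapiens), read by microscopy (a higher number here means that more compound is tolerated, a lower number that less compound is tolerated), compound 2 gives 400000 nM. For the measured compounds named here, the only other compound measured in this assay is compound 1, `CCCCCCC#Cc1cc2cn(COCCO)c(=O)nc2o1`. In this assay compound 1 gives > 200000 nM, which is a limit of the assay rather than a number. That is the situation behind (the limit of > 200000 nM in this assay, at which 1 of the 2 values shown sits). Going by the values given here, compound 2 thus holds the only actual number in this assay, and no step between two measured compounds is available for comparison.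

Compound 3, `CCCCCCc1cc2cn(COCCO)c(=O)nc2o1`, is the compound still to be measured. Its change from compound 2 is hydrogen in place of methyl on a saturated chain carbon, six bonds along the chain from an aromatic carbon. Among the compounds with values here, with no measured step of this kind to rest on, the change in this assay is expected to stay within the usual scatter, in no particular direction, and the estimated step is no change at the digits printed from compound 2 to compound 3 (within the scatter). Compound 3 is therefore expected to give 400000 nM in this assay, most likely between 200000 nM and 800000 nM.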

Compound 3, minimum cytotoxic concentration: >= 400000 nM
Compound 3: only a limit was reported; the forecaster's own chance of this, stated with the estimate: 40%; the middle value sits exactly at the limit.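

For the compounds shown here, this is the first step available at this position, since the earlier compounds gave no pair that differ in one place. With hydrogen in place of methyl on a saturated chain carbon, six bonds along the chain from an aromatic carbon, this assay gives a number no lower from compound 2 to compound 3 (the limit leaves the size open). The value of compound 3 is a limit of the assay and not a number: the limit of >= 400000 nM in this assay, at which 1 of the 3 values shown sits.

From the compounds shown here alone, the size of this step therefore remains open, and the direction reaches no further than the printed limit allows. Also open, going by these compounds, is how this assay would respond to a longer chain, or to an amine in place of the methyl.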